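Ketone-side aryl variation in a chalcone series

The source may report more compounds than this note shows. Statements on the series, on what has been measured and on what is new or still open speak of the compounds shown alone.

Measured compounds and their values in a functional assay on A2780 cells (Homo sapiens) for cytotoxicity, read by MTT assay, with a stated time of 68 h; a higher number here means a weaker inhibitor, a lower number a stronger inhibitor:
- compound 1, `O=C(/C=C/c1cccc(OCc2ccccc2)c1)c1cccc(Br)c1`: 6300 nM
- compound 2, `O=C(/C=C/c1cccc(OCc2ccccc2)c1)c1ccc(Cl)cc1Cl`: 21400 nM
- compound 3, `O=C(/C=C/c1cccc(OCc2ccccc2)c1)c1ccc([N+](=O)[O-])cc1`: 56400 nM

Compound 1 gives the lowest number of the three in this assay. The nearest is compound 2, reached by a 3.4-fold higher number from compound 1 to compound 2 (0.53 log units; beyond the scatter). The furthest is compound 3, reached by a 9.0-fold higher number from compound 1 to compound 3 (0.95 log units; beyond the scatter); between those two stands a 2.6-fold higher number from compound 2 to compound 3 (0.42 log units; beyond the scatter). All three steps lie beyond the scatter, and every measured replacement of the 3-bromophenyl on the carbonyl carbon has given a higher number.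

Compound 4, `Cc1ccc(C(=O)/C=C/c2cccc(OCc3ccccc3)c2)cc1`, has not yet been measured in this assay. It differs from compound 1 as follows: 4-methylphenyl in place of 3-bromophenyl on a carbonyl carbon. Within the data shown here, no measured pair swaps 3-bromophenyl for 4-methylphenyl, so the two steps from compound 1 bear only indirectly on it; they show that both alternatives to 3-bromophenyl tried so far gave modestly higher numbers.

For compound 4 a modest step in the same direction is expected, a 1.9-fold higher number from compound 1 to compound 4 (0.28 log units; within the scatter), with wide uncertainty because no direct analog exists. The expected value for compound 4 in this assay is 12000 nM, estimated to fall between 5000 nM and 35000 nM.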

Compound 4, half-maximal inhibitory concentration: 20500 nM
Compound 4: middle estimate off by 1.7-fold (0.23 log units), on the low side, and the stated range covers the measured number.
By their numbers in this assay, from the lowest: compound 1; then compounds 4 and 2 (each within the scatter of the next); then compound 3.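

In this assay, 4-methylphenyl on the carbonyl carbon also fails to match 3-bromophenyl, with a 3.3-fold higher number from compound 1 to compound 4 (0.51 log units; beyond the scatter), so a replacement made of carbon only joins the chlorine- and nitro-bearing rings of compounds 2 and 3 in giving a higher number than compound 1. Methyl in place of nitro on an aromatic carbon gives a 2.8-fold lower number from compound 3 to compound 4 (0.44 log units; beyond the scatter), the first step in the series that changes only the group on a 4-substituted ring, while a 1.0-fold lower number from compound 2 to compound 4 (0.02 log units; within the scatter) leaves 4-methylphenyl and 2,4-dichlorophenyl unseparated despite their different groups. No measurement at hand accounts for any of these differences.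

The compounds shown do not tell whether the lower number of compound 1 belongs to the bromine itself or to where it sits on the ring, as no other bromine-bearing ring and no other ring with a group in that place appears among them. As far as these compounds go, how a ring carrying an amine, a carboxylic acid or a methoxy group would read here also stays open, as does whether the ranking holds when the rest of the shared core changes.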